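Furan in place of bromophenyl on the chalcone chain

This account rests on a few compounds, and the source may have more. Where it says the series, first, only, none or still open, it means among the compounds named here.

Three compounds have been measured in a functional assay on HepG2 cells (Homo sapiens) for antiproliferative activity, read by MTT assay, with a stated time of 24 h; on this read-out lower numbers stand for stronger inhibition and higher numbers for weaker inhibition:
Compound 1 `COc1ccc(C(=O)/C=C/c2cccc(F)c2)c2c1C=CC(C)(C)O2` gives > 10000 nM, a limit of the assay.
Compound 2 `COc1ccc(C(=O)/C=C/c2ccc(Br)cc2)c2c1C=CC(C)(C)O2` gives > 10000 nM, a limit of the assay.
Compound 3 `CCN(CC)c1ccc(/C=C/C(=O)c2ccc(OC)c3c2OC(C)(C)C=C3)cc1` gives 590 nM.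

Compound 2 therefore stands at the limit of > 10000 nM in this assay, at which 2 of the 3 values shown sit. Within the data shown here, two steps touch it. The step that the two limits leave unreadable from compound 1 to compound 2 is unreadable. The step of an at least 16-fold lower number from compound 2 to compound 3 (1.22 log units; beyond the scatter) is large. Compound 4 `COc1ccc(C(=O)/C=C/c2ccco2)c2c1C=CC(C)(C)O2` arises from compound 2 through (furan-2-yl in place of 4-bromophenyl on a double-bonded chain carbon bound to a double-bonded chain carbon). Among the measured compounds shown here, no measured step concerns a furan-2-yl group, so the unreadable step and the large diethylamino step give little guidance. Compound 4 is expected to stay near the limit, with a step that the limit leaves unreadable from compound 2 to compound 4 as the estimated step. The estimate for compound 4 is 15000 nM, within 3000 nM to 60000 nM.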

Compound 4, half-maximal inhibitory concentration: > 10000 nM
Compound 4: only a limit was reported (the forecaster's own chance of this, stated with the estimate: 70%); the middle value is on the limit's open side.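

Compound 4 gives only a limit of the assay, as compound 1 and compound 2 do, so neither step to compound 4 can be read: the limit of > 10000 nM in this assay, at which 3 of the 4 values shown sit.

From the compounds shown here alone, whether furan-2-yl differs at all from 4-bromophenyl or 3-fluorophenyl on this chain stays open.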